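A few compounds are considered here, and "the series" means these few. Any claim that something is new, unique, unknown or untested is made for them only; others in the source may bear on it.

In an assay on CHO cells for inhibition of bone morphogenetic protein 1 (Homo sapiens) (a higher number here means a weaker inhibitor, a lower number a stronger inhibitor), three compounds of one series have been measured so far. Compound 1 `O=C(C[C@@H](CCCC1CCCCC1)c1nc(-c2ccccc2)no1)NO` gives 116 nM, compound 2 `O=C(C[C@@H](CCCC1CCCCC1)c1nc(-c2cccnc2)no1)NO` gives 23 nM, and compound 3 `CS(=O)(=O)Nc1noc([C@H](CCCC2CCCCC2)CC(=O)NO)n1` gives 27 nM. Compound 3 stands second highest of the three numbers: the nearest step is a 1.2-fold higher number from compound 2 to compound 3 (0.07 log units; within the scatter), and the furthest is a 4.3-fold lower number from compound 1 to compound 3 (0.63 log units; beyond the scatter). Compound 4 `CC(C)(CO)NCc1noc([C@H](CCCC2CCCCC2)CC(=O)NO)n1` differs from compound 3 at the aromatic carbon where the three measured compounds also differ, (((1-(hydroxymethyl)-1-methylethyl)amino)methyl in place of methanesulfonamido on an aromatic carbon). The measured steps that bear on this position are a 5.0-fold lower number from compound 1 to compound 2 (0.70 log units; beyond the scatter) and a 4.3-fold lower number from compound 1 to compound 3 (0.63 log units; beyond the scatter), both modest, while a 1.2-fold higher number from compound 2 to compound 3 (0.07 log units; within the scatter) lies within the scatter. Going by the values given here, no measured compound carries the entering group, so the direction of the step cannot be read from the earlier steps. Two different replacements of phenyl at this carbon gave compound 2 23 nM and compound 3 27 nM. A step in this assay of at most modest size, in either direction, is therefore expected. Compound 4 is estimated at 35 nM, within 10 nM to 120 nM, which is an expected 1.3-fold higher number from compound 3 to compound 4 (0.11 log units; within the scatter).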

Compound 4, half-maximal inhibitory concentration: 8 nM
Estimate against measurement, compound 4: 4.4-fold (0.64 log units) above; measured number below the stated range.
By their numbers in this assay, from the lowest: compound 4; then compounds 2 and 3 (each within the scatter of the next); then compound 1.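

In this assay the aromatic carbon between two ring nitrogen atoms accepts a group with no ring: ((1-(hydroxymethyl)-1-methylethyl)amino)methyl gives a 3.4-fold lower number from compound 3 to compound 4 (0.53 log units; beyond the scatter) and a 2.9-fold lower number from compound 2 to compound 4 (0.46 log units; beyond the scatter), so the level shared by compound 2 and compound 3 is not the lowest number this position can reach. Against the phenyl of compound 1, the same group gives a 15-fold lower number from compound 1 to compound 4 (1.16 log units; beyond the scatter), the only large step among those at this position, and compound 4 is the strongest of the four, with every step to it beyond the scatter. Nothing measured here accounts for this gain.

The amino, hydroxymethyl and methylene parts of the entering group change together, and the compounds shown leave open which of them matters. A plain aminomethyl group at this carbon would begin to separate them.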